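Adding a Methylpiperazine to a Core with Low Numbers in This Assay

The compounds below may be only part of what the source reports. "The series", "measured", "known", "first", "only" and "open" are said of these compounds alone.

For the measured compounds named here, in an assay on isolated protein for inhibition of MAP kinase-activated protein kinase 2 (Homo sapiens), read by mobility shift assay, tested at 30 uM (on this read-out higher numbers stand for more inhibition at the one concentration tested (going by the name of the read-out) and lower numbers for less inhibition), compound 1 `CC(C)(C)c1cc2nn(-c3ccccc3)c(N)c2c(=O)[nH]1` gives 6% and compound 2 `Nc1c2c(=O)[nH]c(-c3ccccc3)cc2nn1-c1ccccc1` gives 2%, so compound 2 stands level with compound 1 within the scatter; the single measured step, a number 4 percentage points lower from compound 1 to compound 2 (within the scatter), stays inside that scatter. Compound 3 `CN1CCN(c2ccc(-c3cc4nn(-c5ccccc5)c(N)c4c(=O)[nH]3)cc2)CC1` differs from compound 2 by 4-methylpiperazin-1-yl in place of hydrogen on an aromatic carbon. Going by the values given here, no measured step concerns this kind of change, and the only step at hand is flat. Compound 3 is therefore expected to show a number 3 percentage points higher from compound 2 to compound 3 (within the scatter), nothing beyond the scatter. The estimated inhibition of compound 3 in this assay is 5%, within 0% to 20%.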

Compound 3, a percentage reported as inhibition, at one concentration (the size of the read-out at that concentration, not a potency): 4%
The estimate for compound 3 lay 1 percentage points above the measured number; measured number inside the range.
By their numbers in this assay, from the lowest: compounds 2, 3 and 1 (each within the scatter of the next).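

In this assay, 4-methylpiperazin-1-yl in place of hydrogen on an aromatic carbon, para to a large group, gives a number 2 percentage points higher from compound 2 to compound 3 (within the scatter). This is the first substituent shown on this six-membered aromatic ring of carbon only, and with its non-aromatic ring added, compound 3 stands level with compound 2 within the scatter. No evidence is available that bears on this result. From the compounds shown here alone, whether a carboxylic acid or a longer chain ending in an amine at this place would move the number beyond the scatter stays open, as does the outcome of any change elsewhere on the shared core.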